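Lengthening the isothiocyanate tether on a kinase-like scaffold

The compounds below may be only part of what the source reports. "The series", "measured", "known", "first", "only" and "open" are said of these compounds alone.

Of the compounds shown here, three have been measured in a functional assay on A549 cells (Homo sapiens) for inhibition, read by CCK-8 assay, with a stated time of 72 h, tested at 10 uM; on this read-out lower numbers stand for a weaker effect and higher numbers for a stronger effect at the one concentration tested. Compound 1 `CN(C)C(=O)c1cc2cnc(Nc3ccc(C(=O)NCCCCCCN=C=S)cc3F)nc2n1C1CCCC1` gives 22.9%. Compound 2 `CN(C)C(=O)c1cc2cnc(Nc3ccc(C(=O)NCCCCCCCN=C=S)cc3F)nc2n1C1CCCC1` differs from compound 1 by a group of 4 heavy atoms (2 carbon, 1 nitrogen, 1 sulfur; no ring) in place of a group of 3 heavy atoms (1 carbon, 1 nitrogen, 1 sulfur; no ring), on a saturated chain carbon, six bonds along the chain from an amide-type nitrogen; in this assay compound 2 gives 12.7%. The step of a number 10.2 percentage points lower from compound 1 to compound 2 (beyond the scatter) is therefore the one measured effect of this kind of change. Compound 3 `CN(C)C(=O)c1cc2cnc(Nc3ccc(C(=O)NCCCCN=C=S)cc3O)nc2n1C1CCCC1` gives 41.7%, the highest of the three numbers; the difference between its core and that of compound 1 is not broken down here.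

Compound 4 `CN(C)C(=O)c1cc2cnc(Nc3ccc(C(=O)NCCCCCN=C=S)cc3O)nc2n1C1CCCC1` has not yet been measured. It differs from compound 3 by a group of 4 heavy atoms (2 carbon, 1 nitrogen, 1 sulfur; no ring) in place of a group of 3 heavy atoms (1 carbon, 1 nitrogen, 1 sulfur; no ring), on a saturated chain carbon, four bonds along the chain from an amide-type nitrogen. Among the compounds with values here, this is the same kind of change as the one from compound 1 to compound 2, but not the same change, since there the group sits six bonds along the chain from the amide-type nitrogen, whereas here it sits four bonds along the chain from the amide-type nitrogen, and the two cores differ in a way that is not counted.

The expectation rests on one step only, so it is uncertain. In this assay compound 4 is expected to give 32%, within a range from 18% to 46%, because compound 3 gives 41.7% and the added chain carbon lowered the read-out in the earlier pair. The expected step of a number 9.7 percentage points lower from compound 3 to compound 4 (within the scatter) is of about the size of the earlier one, but the shorter chain and the different core could make it smaller or larger.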

Compound 4, a percentage reported as inhibition, at one concentration (the size of the read-out at that concentration, not a potency): 30.7%
For compound 4 the middle estimate is 1.3 percentage points above the measured one; measured number inside the range.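

In this assay, the group of 4 heavy atoms in place of the group of 3 heavy atoms, four bonds along the chain from the amide-type nitrogen, gives a number 11 percentage points lower from compound 3 to compound 4 (beyond the scatter). Lengthening the chain that ends in the isothiocyanate therefore lowers the read-out by a matching amount on both cores shown: the same change on two cores in this assay, a number 10.2 percentage points lower (beyond the scatter) from compound 1 to compound 2 and a number 11 percentage points lower (beyond the scatter) from compound 3 to compound 4, 0.8 percentage points apart, within the scatter of two such steps. Within the data shown here, this is still only two pairs, each at a different chain length, so it does not show that the step would hold on other cores or at other chain lengths, and it says nothing about why the read-out falls, nor about potency, since each number comes from a single concentration.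

From the compounds shown here alone, it remains open whether the read-out would keep falling with a longer chain on the core of compound 3, and whether an amine or a carboxylic acid at the chain end in place of the isothiocyanate would keep any of the effect. Also open is how much the difference between the two cores contributes by itself, since no two compounds shown carry the same chain on both cores.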